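Ethoxycarbonyl to acetoxymethyl on the shared core: an estimate

The source may hold more compounds than are shown below. What is called first, only, known or untested is meant among the compounds shown, and "the series" means these compounds.

Measured so far in a functional assay on A549 cells (Homo sapiens) for cytotoxicity, read by MTT assay, with a stated time of 72 h; a lower number here means that less compound is needed, a higher number that more compound is needed for the effect:
- compound 1, `CCS[C@@H]1[C@H](SCC)[C@@H](Cn2cc(-c3ccc(F)cc3)nn2)O[C@H]1n1ccc(=O)[nH]c1=O`, gives 22900 nM in this assay
- compound 2, `CCOC(=O)c1cn(C[C@H]2O[C@@H](n3ccc(=O)[nH]c3=O)[C@H](SCC)[C@@H]2SCC)nn1`, is reported in this assay only as a limit, >= 100000 nM

Compound 2 therefore has no exact number in this assay; it sits at the limit of >= 100000 nM in this assay, at which 1 of the 2 values shown sits. Within the data shown here, the one measured step that leads to it, an at least 4.3-fold higher number from compound 1 to compound 2 (0.64 log units; beyond the scatter), shows that replacing the 4-fluorophenyl group with ethoxycarbonyl raised the number at least modestly, beyond the scatter.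

Compound 3, `CCS[C@@H]1[C@H](SCC)[C@@H](Cn2cc(COC(C)=O)nn2)O[C@H]1n1ccc(=O)[nH]c1=O`, differs from compound 2 by acetoxymethyl in place of ethoxycarbonyl on an aromatic carbon. Among the measured compounds shown here, no measured step covers this particular exchange, so the only guide is that compound 2 already sits at the limit of this assay and that the group entering is of the same size and count as the one leaving. The step from compound 2 to compound 3 is expected to be small, a number no higher from compound 2 to compound 3 (the limit leaves the size open), with no direction that can be argued from the data.

Compound 3 is therefore estimated at 100000 nM in this assay, in a range of 30000 nM to 300000 nM, and a further limit rather than a number is quite possible.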

Compound 3, half-maximal effective concentration: >= 100000 nM
Compound 3 ended at the assay's limit (the forecaster's own chance of this, stated with the estimate: 65%); the middle value sits exactly at the limit.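

Across the shared core in this assay, putting acetoxymethyl in place of 4-fluorophenyl on this aromatic carbon gives an at least 4.3-fold higher number from compound 1 to compound 3 (0.64 log units; beyond the scatter), so the rise seen with ethoxycarbonyl is no longer the result of a single group. The step from compound 2 to compound 3 cannot be read, as both values are limits, and so nothing can be said about how acetoxymethyl and ethoxycarbonyl compare, even though the two groups have the same atoms, joined differently. Among the compounds shown, compound 1 with its 4-fluorophenyl group is now the only one with an exact number, while the two compounds carrying a group with no ring at this position both stand at the limit: the limit of >= 100000 nM in this assay, at which 2 of the 3 values shown sit.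

The compounds shown leave open whether the exact number in compound 1 depends on the ring as such or on its fluorine, a question that plain phenyl or 4-methoxyphenyl at the same carbon would address. They also leave open whether any group without a ring can bring the number down from the limit, for instance an amine, a carboxylic acid or a longer alkyl chain.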